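The source may report more compounds than this note shows. Statements on the series, on what has been measured and on what is new or still open speak of the compounds shown alone.

Measured in a physicochemical assay for lipophilicity; a lower number here means a more polar compound, a higher number a more lipophilic compound:
- compound 1 `C=C(c1ccc2ccccc2c1)C1CCC2(CC1)COC(Nc1ccccc1)OO2`: 5.59
- compound 2 `C=C(c1ccc2ccccc2c1)C1CCC2(CC1)COC(Nc1ccc(C)cc1)OO2`: 6.08

Of these two, compound 2 stands higher at 6.08. Among the compounds with values here, the only measured step is a number 0.49 log units higher from compound 1 to compound 2 (beyond the scatter), for methyl in place of hydrogen on an aromatic carbon.

Next is compound 3 `C=C(c1ccc2ccccc2c1)C1CCC2(CC1)COC(Nc1ccccc1-c1ccccc1)OO2`, which has 2-phenylphenyl in place of 4-methylphenyl on an amine nitrogen. Within the data shown here, no measured step covers this exchange directly. Among the measured compounds shown here, the closest guide is the single methyl step, a number 0.49 log units higher from compound 1 to compound 2 (beyond the scatter), where added carbon went with a higher number. The entering group holds more carbon than the leaving one, so a rise in this assay larger than that step is expected, though one step is thin support. The expected change is a number 0.92 log units higher from compound 2 to compound 3 (beyond the scatter). For compound 3 the estimated value is 7, with an estimated range of 6.5 to 7.5.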

Compound 3, partition coefficient: 7.26
Compound 3: the middle estimate sits 0.26 log units below what was measured; measured number inside the range.
By their numbers in this assay, from the lowest: compound 1; then compound 2; then compound 3.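

In this assay, an added phenyl gives a much bigger step than methyl did (a number 1.67 log units higher from compound 1 to compound 3 (beyond the scatter), against a number 0.49 log units higher from compound 1 to compound 2 (beyond the scatter)). The exchange of 4-methylphenyl for 2-phenylphenyl on the amine nitrogen is also large (a number 1.18 log units higher from compound 2 to compound 3 (beyond the scatter)), so both carbon-only substituents shown go with a higher number than the unsubstituted compound 1, and no compound shown goes against this. Nothing available accounts for the size of these steps.
On these data alone, all the groups compared here are made of carbon only, so the effect on this number of an amine or a carboxylic acid on the same aromatic ring remains open. As far as these compounds go, whether a longer chain would follow the same rise also remains open.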